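The source may report more compounds than this note shows. Statements on the series, on what has been measured and on what is new or still open speak of the compounds shown alone.

The series shares one core, seen first in compound 1 `CN(CC1=CC[C@H]2C[C@@H]1C2(C)C)Cc1ccc(Cl)cc1`, which in an assay on HEK293 cells for displacement of a labelled ligand from C-X-C chemokine receptor type 3 (Homo sapiens) (a higher number here means a weaker inhibitor, a lower number a stronger inhibitor), gives 2510 nM. Compound 2 `CN(CC1=CC[C@H]2C[C@@H]1C2(C)C)Cc1ccc(-c2cccc(F)c2)cc1`, where a 3-fluorophenyl replaces the chloro on the aromatic carbon, gives 2510 nM in this assay, so that no change at the digits printed from compound 1 to compound 2 (within the scatter). Compound 3 `CN(CC1=CC[C@H]2C[C@@H]1C2(C)C)Cc1ccc(-c2cccc(C(F)(F)F)c2)cc1` carries a trifluoromethyl in place of that fluoro. In this assay compound 3 gives > 316 nM, which is a limit of the assay and not a number. The step that the limit leaves unreadable from compound 2 to compound 3 therefore cannot be sized, because of the limit of > 316 nM in this assay, at which 1 of the 3 values shown sits.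

Compound 4 `CN(CC1=CC[C@H]2C[C@@H]1C2(C)C)Cc1ccc(-c2cccc(Cl)c2)cc1` differs from compound 3 in one place: chloro in place of trifluoromethyl on an aromatic carbon. Of the two measured steps, only the first is readable, and it shows no change beyond the scatter; the second is hidden by the limit. Compound 3 stands only at a limit, with no number to step from. The expectation for compound 4 rests on compound 1 and compound 2, whose values in this assay sit close together, and on the fact that the change is a small swap on the same aromatic carbon. Compound 4 is therefore expected to give about 2000 nM in this assay, between 500 nM and 8000 nM. Measured from the limit, this expected change is a step that the limit leaves unreadable from compound 3 to compound 4.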

Compound 4, inhibition constant: 3980 nM
Estimate against measurement, compound 4: 2.0-fold (0.30 log units) below, and the stated range covers the measured number.
By their numbers in this assay, from the lowest: compounds 1, 2 and 4 (each within the scatter of the next).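

In this assay, chloro in place of fluoro on this aromatic carbon gives a 1.6-fold higher number from compound 2 to compound 4 (0.20 log units; within the scatter), so a second substituent on the added phenyl ring leaves the number within the scatter. The 3-chlorophenyl in place of the chloro of compound 1 gives a 1.6-fold higher number from compound 1 to compound 4 (0.20 log units; within the scatter), which matches what the 3-fluorophenyl showed and means that compounds 1, 2 and 4 give no readable separation at all, whichever of these groups they carry. The step from compound 3 to compound 4 cannot be read, any more than the step into compound 3, because compound 3 stands only at a limit and not at a number: the limit of > 316 nM in this assay, at which 1 of the 4 values shown sits.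

The compounds shown leave open whether trifluoromethyl at this place differs at all from chloro or fluoro, since compound 3 gives no number to compare. They also leave open whether a group of another kind on this aromatic carbon, such as an amine, a carboxylic acid or a nitrile, would move the value beyond the scatter, as no group shown here has done.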